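The source may hold more compounds than are shown below. What is called first, only, known or untested is meant among the compounds shown, and "the series" means these compounds.

Working notes on the series. Compound 1 `CC(C)C[C@H](NC(=O)OCc1cccc(F)c1)C(=O)N[C@H](C=O)C[C@@H]1CCNC1=O` carries formyl on a saturated chain carbon bound to an amide-type nitrogen and a saturated chain carbon. In an ADME assay on HEK-293T cells (Homo sapiens) for cytotoxicity, with a stated time of 72 h (on this read-out lower numbers stand for higher toxicity in this test and higher numbers for lower toxicity in this test), compound 1 returns only a limit, > 100000 nM. Compound 2 `CC(C)C[C@H](NC(=O)OCc1cccc(F)c1)C(=O)N[C@@H](C[C@@H]1CCNC1=O)C(O)S(=O)(=O)O` differs from it by hydroxy(sulfo)methyl in place of formyl on a saturated chain carbon bound to an amide-type nitrogen and a saturated chain carbon. In this assay compound 2 likewise stops at a limit, > 100000 nM. The step that the two limits leave unreadable from compound 1 to compound 2 is thus unreadable. Compound 3 `CCCC(OC(=O)N[C@@H](CC(C)C)C(=O)N[C@H](C=O)C[C@@H]1CCNC1=O)c1ccccc1` differs from compound 1 by 1-phenylbutyl in place of 3-fluorobenzyl on an oxygen next to a carbonyl group. In this assay compound 3 also sits at a limit, > 100000 nM. The step that the two limits leave unreadable from compound 1 to compound 3 cannot be sized either; all three values share (the limit of > 100000 nM in this assay, at which 3 of the 3 values shown sit).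

Compound 4 `CCCC(OC(=O)N[C@@H](CC(C)C)C(=O)N[C@@H](C[C@@H]1CCNC1=O)C(O)S(=O)(=O)O)c1ccccc1` is not yet measured. It differs from compound 3 by hydroxy(sulfo)methyl in place of formyl on a saturated chain carbon bound to an amide-type nitrogen and a saturated chain carbon, the same change as from compound 1 to compound 2, with the place described in identical words. Since compound 2 stops at > 100000 nM, compound 4 is expected to stop at the limit too. The expected step is a step that the limit leaves unreadable from compound 3 to compound 4. Compound 4 is estimated at 150000 nM, expected within 80000 nM to 400000 nM.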

Compound 4, half-maximal cytotoxic concentration: > 100000 nM
Compound 4 gave a limit, no number; the forecaster's own chance of this, stated with the estimate: 85%; the middle value is on the limit's open side.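

In this assay compound 4 returns only a limit, > 100000 nM, so the steps reaching it from compound 3 and compound 2 cannot be read. Whether either change shifts this read-out stays open, since no compound shown gives a number: the limit of > 100000 nM in this assay, at which 4 of the 4 values shown sit.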